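Changing the formylamino group of compound 2

The compounds below may be only part of what the source reports. "The series", "measured", "known", "first", "only" and "open" are said of these compounds alone.

Measured so far in a functional assay on the whole organism with Rattus norvegicus as the target (a lower number here means that less compound is needed, a higher number that more compound is needed for the effect), for this series:
Compound 1 `CCCNc1cc(OC)c(C(=O)NC2CCN(Cc3ccccc3)C2)cc1Cl` gives 17 mg/kg
Compound 2 `COc1cc(NC=O)c(Cl)cc1C(=O)NC1CCN(Cc2ccccc2)C1` gives 0.6 mg/kg

Compound 2 has the lower number of the two measured compounds in this assay and is the reference point for the next change. Compound 3 `COc1cc(N(C)C(=O)C(F)(F)F)c(Cl)cc1C(=O)NC1CCN(Cc2ccccc2)C1` carries methyl((trifluoromethyl)carbonyl)amino in place of formylamino on an aromatic carbon. Within the data shown here, only one measured step bears on this, and it bears indirectly. That step, a 28-fold lower number from compound 1 to compound 2 (1.45 log units; beyond the scatter), is large and beyond the scatter, and it came from formyl in place of propyl on the same nitrogen. It shows that a change at this nitrogen can shift the number strongly. Among the measured compounds shown here, no measured compound has a methyl or a trifluoromethyl group at this place, so the size of the new step is poorly constrained. Compound 2 already holds the lower number, so a moderate move towards a higher number is expected, and the expected step is a 2.5-fold higher number from compound 2 to compound 3 (0.40 log units; beyond the scatter) (a wide margin remains on both sides). For compound 3 the estimated value is 1.5 mg/kg (expected range 0.3 mg/kg to 8 mg/kg).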

Compound 3, dose for half-maximal effect: 0.3 mg/kg
For compound 3 the middle estimate is 5.0-fold (0.70 log units) above the measured one, within the range that was stated.
By their numbers in this assay, from the lowest: compounds 3 and 2 (each within the scatter of the next); then compound 1.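

In this assay, the step of a 2.0-fold lower number from compound 2 to compound 3 (0.30 log units; within the scatter) shows that this position tolerates a much larger group on the aromatic carbon: methyl((trifluoromethyl)carbonyl)amino has 8 heavy atoms and 0 hydrogen-bond donors, whereas formylamino has 3 heavy atoms and 1 hydrogen-bond donor. In these two compounds, therefore, a hydrogen-bond donor on this nitrogen is not needed to keep the number at this level, and the earlier step alone could not show that. The step of a 57-fold lower number from compound 1 to compound 3 (1.75 log units; beyond the scatter) places compound 3 on the same side of the large gap from compound 1 as compound 2, so among the three compounds, those with a carbonyl on this nitrogen hold the low numbers and none goes against this, while no measurement available here accounts for the differences.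

The parts played by the methyl on the nitrogen and the trifluoromethyl on the carbonyl remain unseparated, as compound 3 introduces them together. As far as these compounds go, it also remains open whether a plain amino group, an acetyl group or a longer acyl chain at this position would stay with compound 2 and compound 3 or move towards compound 1.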